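Bromo Added to the Nitrile Anilide Core

The source may hold more compounds than are shown below. What is called first, only, known or untested is meant among the compounds shown, and "the series" means these compounds.

Compound 2 `O=C(Nc1cc(C(F)(F)F)cc(C(F)(F)F)c1)c1ccc(-c2ccccc2)cc1O` gives 1140 nM in a functional assay on HL-60 cells (Homo sapiens) for cytotoxicity, read by luminescence and CellTiter-Glo, with a stated time of 3 days; a higher number here means a weaker inhibitor, a lower number a stronger inhibitor. Compound 1 `O=C(Nc1cc(C(F)(F)F)cc(C(F)(F)F)c1)c1cc(Br)c(-c2ccccc2)cc1O` differs from it by bromo in place of hydrogen on an aromatic carbon; in this assay compound 1 gives 430 nM, which is a 2.7-fold lower number from compound 2 to compound 1 (0.42 log units; beyond the scatter). Compound 3 `N#Cc1ccc(NC(=O)c2ccc(-c3ccccc3)cc2O)cc1` carries a different amide partner, and the difference between the two cores is not broken down here; in this assay compound 3 gives 700 nM. Compound 4 `N#Cc1ccc(NC(=O)c2cc(Br)c(-c3ccccc3)cc2O)cc1` has not been measured. It carries bromo in place of hydrogen on an aromatic carbon, the same change already made between compound 2 and compound 1. A step of similar size is expected, namely a 2.6-fold lower number from compound 3 to compound 4 (0.41 log units; beyond the scatter), because the same change earlier gave a 2.7-fold lower number from compound 2 to compound 1 (0.42 log units; beyond the scatter). Compound 4 is therefore estimated at 270 nM in this assay, expected to fall between 110 nM and 650 nM.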

Compound 4, half-maximal inhibitory concentration: 700 nM
Beside the measured number, compound 4's estimate is 2.6-fold (0.41 log units) below it; the measured number lies above the stated range.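

On the core of compound 3, bromo in place of hydrogen on an aromatic carbon gives no change at the digits printed from compound 3 to compound 4 (within the scatter) in this assay. Set beside the earlier step, the result does not separate the two cores: the same change on two cores in this assay, a 2.7-fold lower number (0.42 log units; beyond the scatter) from compound 2 to compound 1 and no change at the digits printed (within the scatter) from compound 3 to compound 4, 2.7-fold (0.42 log units) apart, within the scatter of two such steps The pairs therefore do not show that the step seen on the core of compound 2 carries over to the core of compound 3, nor do they show that the two cores respond differently, as each core offers a single pair.

The compounds shown leave open how a chloro, a methyl or an amine on the same aromatic carbon would read on either core. They also leave open whether the bromo step would hold with a third amide partner, such as an aniline bearing a carboxylic acid.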